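The compounds below may be only part of what the source reports. "The series", "measured", "known", "first", "only" and "open" are said of these compounds alone.

Measured compounds:
- compound 1 `O=C(NCCCCc1ccccc1)n1cc(-c2ccccc2)oc1=O`: 90 nM
- compound 2 `O=C(NCCCCc1ccccc1)n1cc(-c2ccncc2)oc1=O`: 18 nM
- compound 3 `O=C(NCCCCc1ccccc1)n1cc(-c2nccs2)oc1=O`: 59 nM

In an assay on isolated protein for inhibition of acid ceramidase (Homo sapiens), read by LC-MS, with a stated time of 1 h (a higher number here means a weaker inhibitor, a lower number a stronger inhibitor), compound 3 gives the second highest of the three numbers; its nearest neighbour is compound 1, from which it differs within the scatter, and compound 2 stands apart, as a 3.3-fold higher number from compound 2 to compound 3 (0.52 log units; beyond the scatter) shows. Compound 4 `CN1CCC(c2cn(C(=O)NCCCCc3ccccc3)c(=O)o2)CC1` arises from compound 3 by 1-methylpiperidin-4-yl in place of 1,3-thiazol-2-yl on an aromatic carbon. For the measured compounds named here, no measured step exchanges an aromatic ring for a non-aromatic one; the steps on hand, a 5.0-fold lower number from compound 1 to compound 2 (0.70 log units; beyond the scatter) and a 1.5-fold lower number from compound 1 to compound 3 (0.18 log units; within the scatter), only compare aromatic rings at this position. The bearing on compound 4 is therefore weak, and a step of modest size in either direction in this assay is plausible. For compound 4 the expected step is a 1.4-fold higher number from compound 3 to compound 4 (0.13 log units; within the scatter), with an estimated value of 80 nM and a range from 20 nM to 320 nM.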

Compound 4, half-maximal inhibitory concentration: 1400 nM
The estimate for compound 4 lay 18-fold (1.24 log units) below the measured number; the whole stated range lies below it.
By their numbers in this assay, from the lowest: compound 2; then compounds 3 and 1 (each within the scatter of the next); then compound 4.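

For the compounds shown here, compound 4 is the first with a non-aromatic ring on the aromatic carbon next to the ring oxygen, and in this assay this exchange gives larger steps than any exchange among the aromatic rings: a 24-fold higher number from compound 3 to compound 4 (1.38 log units; beyond the scatter), a 16-fold higher number from compound 1 to compound 4 (1.19 log units; beyond the scatter) and a 78-fold higher number from compound 2 to compound 4 (1.89 log units; beyond the scatter). Among the compounds shown, this position separates the 1-methylpiperidin-4-yl from the aromatic rings by more than it separates those rings from one another. Nothing at hand gives a reason for this loss.

From the compounds shown here alone, the non-aromatic ring and its methyl-bearing nitrogen enter together, so their shares in the step stay open. A cyclohexyl ring or a piperidin-4-yl without the methyl would separate them.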